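The source may report more compounds than this note shows. Statements on the series, on what has been measured and on what is new or still open speak of the compounds shown alone.

Working notes on the series. Three compounds sharing one core have numbers in a functional assay on the whole organism with Rattus norvegicus as the target, with a stated time of 4 h, at a dose of 40 mg/kg by the intraperitoneal route; a higher number here means more inhibition at the dose given (going by the name of the read-out), a lower number less inhibition. Compound 1 `Cc1nc2c(CSc3ccccc3)cccn2c1C` gives 29% in this assay. Compound 2 `Cc1nc2c(C[S+]([O-])c3ccccc3)cccn2c1C` gives 42% in this assay. Compound 3 `Cc1nc2c(OCc3ccccc3)cccn2c1C#N` gives 25% in this assay. Where compound 3 stands: its number and that of compound 1 lie within the usual scatter of each other, so no order between those two is claimed; compound 2 lies beyond the scatter above compound 3. Among the measured compounds shown here, the three measured compounds differ from one another at more than one place at once, so no single-point step between measured compounds is available, and no part of the spread can be tied to one change.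

Compound 4 `CCOCc1c(C)nc2c(OCc3ccccc3)cccn12` differs from compound 3 in one place: ethoxymethyl in place of cyano on an aromatic carbon. For the measured compounds named here, nothing measured shows the effect of this exchange, since no pair of measured compounds differs by it alone. In this assay the step is therefore expected to be small, not clearly in either direction, and within the scatter; the estimated step of a number 5 percentage points higher from compound 3 to compound 4 (within the scatter) from compound 3 to compound 4 reflects that. Compound 4 is expected to give about 30% in this assay, with a range from 10% to 50%.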

Compound 4, a percentage reported as inhibition, in the whole organism at one dose (the size of the read-out at that dose, not a potency): 84%
Compound 4: middle estimate off by 54 percentage points, on the low side; the whole stated range lies below it.
By their numbers in this assay, from the lowest: compounds 3 and 1 (each within the scatter of the next); then compound 2; then compound 4.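

In this assay, among the compounds shown here, ethoxymethyl in place of cyano on an aromatic carbon of the five-membered ring gives a number 59 percentage points higher from compound 3 to compound 4 (beyond the scatter) and is the only single-place step so far. The earlier compounds shown here could not show it, but this place, next to the ring nitrogen and next to the ring atom that bears a methyl group, clearly matters for the read-out at this dose, even though the exchange leaves the counts of hydrogen-bond donors and acceptors and the net charge the same and adds no ring. Nothing available on the compounds explains the size of this step.

Still open, as far as these compounds go, is whether the step belongs to the ether oxygen, to the longer chain or to the loss of cyano; a methoxymethyl group, a plain propyl chain, an aminomethyl group or a carboxylic acid at this place would help to separate these readings. Also open, from the compounds shown here alone, is whether ethoxymethyl at this place gives a similar step when the benzyloxy group of compound 4 is replaced by the side chain of compound 1 or of compound 2.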